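From propyl to 4-methylphenyl on the shared core

The source may hold more compounds than are shown below. What is called first, only, known or untested is meant among the compounds shown, and "the series" means these compounds.

Measured compounds:
compound 1 `CCCn1ccnc1-c1cc(OC)c(OC)c(OC)c1`: > 100000 nM
compound 2 `COc1cc(-c2nccn2S(=O)(=O)c2ccccc2)cc(OC)c1OC`: > 100000 nM
compound 3 `COc1cc(-c2nccn2-c2ccc3sccc3c2)cc(OC)c1OC`: 16800 nM

All three compounds were tested in a functional assay on MDA-MB-231 cells (Homo sapiens) for antiproliferative activity, read by MTT assay, with a stated time of 72 h; on this read-out higher numbers stand for weaker inhibition and lower numbers for stronger inhibition. Compound 1 stands at > 100000 nM, which is a limit of the assay and not a number. Compound 2 gives > 100000 nM, and this too is a limit. The set therefore shows (the limit of > 100000 nM in this assay, at which 2 of the 3 values shown sit). Only compound 3 gives a number, 16800 nM.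

Compound 4 `COc1cc(-c2nccn2-c2ccc(C)cc2)cc(OC)c1OC` keeps the shared core of compound 1 and carries 4-methylphenyl in place of propyl on an aromatic nitrogen. Among the measured compounds shown here, no two measured compounds differ in one place, so the size of this change can only be judged indirectly. Compound 3, at 16800 nM, has an aromatic ring directly on that nitrogen, which points to some gain in this assay. Compound 2 also holds a ring in its substituent on that nitrogen and goes against this reading, so a result at the limit remains possible. The expected change is moderate and towards stronger inhibition, estimated as an at least 4.0-fold lower number from compound 1 to compound 4 (0.60 log units; beyond the scatter). For compound 4 the estimated value is 25000 nM, with an expected range from 4000 nM to 100000 nM.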

Compound 4, half-maximal inhibitory concentration: 4100 nM
For compound 4 the middle estimate is 6.1-fold (0.79 log units) above the measured one; the measured number falls inside the stated range.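

In this assay, among the compounds shown here, the change on the aromatic nitrogen gives the first step in this set that can be read, and it shows that this position can take the read-out off the limit: 4-methylphenyl in place of propyl brings an at least 24-fold lower number from compound 1 to compound 4 (1.38 log units; beyond the scatter). Compound 1 stands at > 100000 nM, which is a limit of the assay and not a number. The step therefore gives only the least size of the change and not its true size, because one of its two ends rests on that limit: the limit of > 100000 nM in this assay, at which 2 of the 4 values shown sit.

The compounds shown leave open whether the gain belongs to the aromatic ring or simply to a larger group on that nitrogen, and a longer chain such as hexyl in the same place would separate the two. From the compounds shown here alone, what the methyl of the 4-methylphenyl group adds also stays open, and a plain phenyl or a 4-methoxyphenyl group on that nitrogen would speak to that question.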